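The source may hold more compounds than are shown below. What is called first, only, known or untested is meant among the compounds shown, and "the series" means these compounds.

Compound 2 `Cc1cc(-c2c(C)nn(C)c2C)ccc1-c1nnc(N(C)Cc2ccc3ncc(-c4ccccc4)n3c2)o1` has the longer of the two half-lives measured so far in a physicochemical assay for pharmacokinetics (a lower number here means that the compound disappears faster, a higher number that the compound lasts longer), namely 273 h. Compound 1 `Cc1cc(-c2c(C)nn(C)c2C)ccc1-c1nnc(N(C)Cc2ccc3nccn3c2)o1` carries a hydrogen where compound 2 carries a phenyl; in this assay compound 1 gives 69 h. Within the data shown here, the one step on record is a 4.0-fold higher number from compound 1 to compound 2 (0.60 log units; beyond the scatter), a change that goes beyond the usual scatter.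

Compound 3 `Cc1cc(-c2c(C)nn(C)c2C)ccc1-c1nnc(N(C)Cc2ccc3ncc(-c4cnn(C)c4)n3c2)o1` is the next compound, and its change from compound 2 is this: 1-methyl-1H-pyrazol-4-yl in place of phenyl on an aromatic carbon. The fused two-ring system, its methylated amine linker and the rest of the shared core stay the same.

Among the measured compounds shown here, the only step that bears on this is the one from compound 1 to compound 2, which shows that filling this position with a six-membered aromatic ring lengthens the half-life. For the measured compounds named here, no measured pair shows what happens when one aromatic ring is swapped for another at this position. Compound 3 is therefore expected to stay between the two measured values, with a half-life estimated at 150 h, within a range of 60 h to 400 h, which means an expected step of a 1.8-fold lower number from compound 2 to compound 3 (0.26 log units; within the scatter).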

Compound 3, half-life: 273 h
The estimate for compound 3 lay 1.8-fold (0.26 log units) below the measured number; the range from low to high includes it.
By their numbers in this assay, from the lowest: compound 1; then compounds 2 and 3 (each within the scatter of the next).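

In this assay, putting 1-methyl-1H-pyrazol-4-yl in place of phenyl gives no change at the digits printed from compound 2 to compound 3 (within the scatter), so on this aromatic carbon a six-membered aromatic ring of carbon only and a five-membered aromatic ring with 2 hetero atoms cannot be told apart by half-life. Measured against the hydrogen of the unsubstituted compound, the new group gives a 4.0-fold higher number from compound 1 to compound 3 (0.60 log units; beyond the scatter), the same rise as phenyl gave, which shows that the longer half-life is not tied to phenyl alone, even though 1-methyl-1H-pyrazol-4-yl has 2 hydrogen-bond acceptors and phenyl has none. No measurement at hand explains why these two rings give the same number.

The compounds shown leave open whether an aromatic ring is needed here at all, since a small methyl group, an amine or a carboxylic acid on this carbon would test whether any replacement for hydrogen gives a similar rise. Also open, going by these compounds, is how far this tolerance extends among rings, for example whether a pyridyl ring or a saturated ring such as piperidine would match the two aromatic groups seen so far.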